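Sec-butyl to isobutyl on the enaminone nitrogen

The compounds below may be only part of what the source reports. "The series", "measured", "known", "first", "only" and "open" are said of these compounds alone.

Measured so far:
compound 1 `CCC(C)NC(=C\C(=O)/C=C/c1ccc(O)c(OC)c1)/C=C/c1ccc(O)c(OC)c1` gives 85%
compound 2 `O=C(/C=C(/C=C/c1ccc(O)cc1)NC1CCCCC1)/C=C/c1ccc(O)cc1` gives 129%

In a functional assay on EA.hy 926 cells (Homo sapiens), read by fluorescence, tested at 1 uM (on this read-out lower numbers stand for a weaker effect and higher numbers for a stronger effect at the one concentration tested), compound 1 stands lowest of the two numbers; compound 2 gives 129%, a difference that lies beyond the usual scatter of such readings. Compound 3 `COc1cc(/C=C/C(=O)/C=C(/C=C/c2ccc(O)c(OC)c2)NCC(C)C)ccc1O` has the same atoms as compound 1, joined differently: isobutyl in place of sec-butyl on an amine nitrogen. Both chains carry the same count of carbons and no ring, donor or acceptor, so the step of a number 3 percentage points higher from compound 1 to compound 3 (within the scatter) is expected to be small, with no direction beyond the scatter. Compound 3 is estimated at 88%, between 62% and 114%.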

Compound 3, a percentage reported as activity, at one concentration (the size of the read-out at that concentration, not a potency): 83%
For compound 3 the middle estimate is 5 percentage points above the measured one; the range from low to high includes it.
By their numbers in this assay, from the lowest: compounds 3 and 1 (each within the scatter of the next); then compound 2.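

In this assay, the change to isobutyl on an amine nitrogen gives a number 2 percentage points lower from compound 1 to compound 3 (within the scatter), so moving from one branched butyl chain to the other leaves the read-out unchanged within the scatter. For the compounds shown here, this is the first single-place comparison, as compound 2 differs from compound 1 in more than one place. Nothing measured here offers an explanation for this result.

As far as these compounds go, whether a straight n-butyl chain or a chain ending in a carboxylic acid on this nitrogen would shift the read-out beyond the scatter remains open. Also open, from the compounds shown here alone, is how much of the higher value of compound 2 belongs to its cyclohexyl.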